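The source may report more compounds than this note shows. Statements on the series, on what has been measured and on what is new or still open speak of the compounds shown alone.

Of the compounds shown here, two have been measured so far. Compound 1 `COc1cc(/C=N/NC(=O)CCN2CCN(c3ccnc4cc(Cl)ccc34)CC2)ccc1OC(C)C` and compound 2 `O=C(CCN1CCN(c2ccnc3cc(Cl)ccc23)CC1)N/N=C/c1ccccc1Cl` share one core and differ only in the aromatic ring attached to the carbon that carries a double bond to nitrogen. In a physicochemical assay for inhibition, read by spectrophotometry, with a stated time of 24 h, tested at 2.5 mM (on this read-out higher numbers stand for more inhibition at the one concentration tested (going by the name of the read-out) and lower numbers for less inhibition), compound 1 gives 15.7%, while compound 2 gives 87.3%. For the measured compounds named here, the one measured step, a number 71.6 percentage points higher from compound 1 to compound 2 (beyond the scatter), is the only comparison available, and it places compound 2 at the top of the two numbers, far from compound 1.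

Compound 3 `CC(C)c1ccc(/C=N/NC(=O)CCN2CCN(c3ccnc4cc(Cl)ccc34)CC2)cc1` is the next member of the series and has not yet been measured. Its change from compound 2 is 4-isopropylphenyl in place of 2-chlorophenyl on a carbon with a double bond to nitrogen.

The measured step bears on this change only loosely, since neither end of it carries a 4-isopropylphenyl group. It does show, however, that swapping the ring at this position can move this assay by a large amount, and that the one ring bearing a substituent at the 4-position gave the low number. On that basis compound 3 is expected to fall below compound 2, with an estimated step of a number 47.3 percentage points lower from compound 2 to compound 3 (beyond the scatter), though the spread of plausible outcomes is wide. The estimate for compound 3 in this assay is 40%, with a range from 10% to 80%.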

Compound 3, a percentage reported as inhibition, at one concentration (the size of the read-out at that concentration, not a potency): 94%
The estimate for compound 3 lay 54 percentage points below the measured number, outside the stated range (above it).
By their numbers in this assay, from the lowest: compound 1; then compounds 2 and 3 (each within the scatter of the next).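

In this assay, replacing the ring on this carbon gives a number 6.7 percentage points higher from compound 2 to compound 3 (within the scatter), so 2-chlorophenyl and 4-isopropylphenyl cannot be told apart here, even though one carries chlorine and the other has only carbon in its added group. The names 4-isopropoxy-3-methoxyphenyl and 4-isopropylphenyl both contain a group numbered 4, yet exchanging the first for the second gives a number 78.3 percentage points higher from compound 1 to compound 3 (beyond the scatter), so a group with that number does not by itself go with a low reading, and compound 1 now stands apart from compound 2 and compound 3. No measurement shown here explains why these rings give the numbers they do.

The compounds shown do not separate the isopropoxy group of compound 1 from its methoxy group, so it remains open whether either one alone goes with the low number. Also open, going by these compounds, is how the reading would respond to a ring bearing an amine or a carboxylic acid, or to a pyridine ring in place of the benzene ring.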